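This account rests on a few compounds, and the source may have more. Where it says the series, first, only, none or still open, it means among the compounds named here.

Compound 1 `CCN1CCc2c(c(C)nn2C(=O)Nc2ccc(Br)cc2)C1` holds the lower of the two numbers recorded, though the gap to its neighbour compound 2 `CCN1CCc2c(c(C)nn2C(=O)Nc2ccc(F)cc2F)C1` lies within the scatter. In a functional assay on the whole organism (strain Swiss albino) for inhibition, with Mus musculus as the target, in the formalin test, with stated times of 30 min and 5 min, at a dose of 100 mg/kg (on this read-out higher numbers stand for more inhibition at the one dose given (going by the name of the read-out) and lower numbers for less inhibition), compound 1 gives 1.7%, and compound 2 gives 7.8%. Compound 3 `CCN1CCc2c(c(C)nn2C(=O)Nc2ccc(Cl)cc2)C1` has yet to be measured; it differs from compound 1 in one place, (chloro in place of bromo on an aromatic carbon). Going by the values given here, no step between two measured compounds that differ in a single place is available, so nothing shows the size of such a change. In this assay the expected step is a number 2.3 percentage points higher from compound 1 to compound 3 (within the scatter), none beyond the scatter. Compound 3 is therefore estimated at 4%, within -8% to 16%.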

Compound 3, a percentage reported as inhibition, in the whole organism at one dose (the size of the read-out at that dose, not a potency): 1.7%
Compound 3: middle estimate off by 2.3 percentage points, on the high side, within the range that was stated.
By their numbers in this assay, from the lowest: compounds 1, 3 and 2 (each within the scatter of the next).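

In this assay the change from 4-bromophenyl to 4-chlorophenyl gives no change at the digits printed from compound 1 to compound 3 (within the scatter) as the first single-place step available, so on this aromatic carbon, para to a large group, chloro and bromo cannot be told apart at this dose. Nothing measured here bears on the reason for this. The compounds shown leave open whether a methoxy group, an amine or a carboxylic acid on this carbon would give a number beyond the scatter, and whether a longer chain in place of the ethyl group would do so.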